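Shortening a chain on the shared core

A few compounds are considered here, and "the series" means these few. Any claim that something is new, unique, unknown or untested is made for them only; others in the source may bear on it.

Compound 1 `CC/N=C(\S)CCn1nc(-c2ccccc2)ccc1=O` gives 100 mg/kg in a functional assay on the whole organism (stomach) with Rattus norvegicus as the target; on this read-out lower numbers stand for an effect already at smaller amounts and higher numbers for an effect only at larger amounts of compound.
Compound 2 `N=C(S)CCCCn1nc(-c2ccccc2)ccc1=O` reaches only a limit of the assay, > 100 mg/kg, in this assay.
Compound 3 `N=C(S)CCCCCCN1N=C(c2ccccc2)CCC1=O` gives 58.8 mg/kg in this assay.

Of the two numbers shown, compound 3 has the lower one, though compound 1 lies within the usual scatter of it, and compound 2 stands at a limit (the limit of > 100 mg/kg in this assay, at which 1 of the 3 values shown sits). Compound 4 `N=C(S)CCN1N=C(c2ccccc2)CCC1=O` differs from compound 3 in one place: a group of 3 heavy atoms (1 carbon, 1 nitrogen, 1 sulfur; no ring) in place of a group of 7 heavy atoms (5 carbon, 1 nitrogen, 1 sulfur; no ring), on a saturated chain carbon, two bonds along the chain from an amide-type nitrogen in a ring. Going by the values given here, the only measured step, a number no lower from compound 1 to compound 2 (the limit leaves the size open), changes a group at a different place and its size cannot be read from the limit, so it gives no guide to this shortening of the chain. Among the compounds with values here, no step of this kind has been measured. Compound 4 is therefore expected to stay close to compound 3, the change being estimated as a 1.0-fold higher number from compound 3 to compound 4 (0.01 log units; within the scatter). The estimate for compound 4 is 60 mg/kg, in the range 20 mg/kg to 150 mg/kg.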

Compound 4, dose for half-maximal effect: > 100 mg/kg
Compound 4: a limit, no number; the forecaster's own chance of this, stated with the estimate: 30%; middle value at least 1.6-fold (0.22 log units) from the limit.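

Shortening the chain on a saturated chain carbon, two bonds along the chain from an amide-type nitrogen in a ring, gives an at least 1.7-fold higher number from compound 3 to compound 4 (0.23 log units; that floor lies within the scatter). Going by these compounds alone, this is the first step measured at this place, and it points towards a higher number, but its floor does not clear the scatter. Compound 4 gives a limit, not a number, and joins compound 2 there: the limit of > 100 mg/kg in this assay, at which 2 of the 4 values shown sit.

As far as these compounds go, the true size of this step stays unknown. From the compounds shown here alone, it also remains open whether a longer chain than in compound 3, or an amine in place of the sulfur-bearing group, would give a lower number.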